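Amide aryl swap in a quinoline antiproliferative series

The source may report more compounds than this note shows. Statements on the series, on what has been measured and on what is new or still open speak of the compounds shown alone.

Measured compounds:
- compound 1 `CCN1CCN(c2cc(C)c3cc(NC(=O)c4cc(Cl)cc(Cl)c4)ccc3n2)CC1`: 6090 nM
- compound 2 `Cc1cc(NCCN2CCN(C)CC2)nc2ccc(NC(=O)c3ccc(Cl)c(Cl)c3)cc12`: 1700 nM

In a functional assay on MCF7 cells (Homo sapiens) for antiproliferative activity, read by MTT assay, with a stated time of 72 h (a lower number here means a stronger inhibitor, a higher number a weaker inhibitor), compound 1 gives 6090 nM, the highest of the two numbers recorded; compound 2 gives 1700 nM, a lower number, and the gap between the two lies beyond the scatter. Compound 1 is therefore the weaker of the two measured compounds. Among the measured compounds shown here, no single-change step between measured compounds is available, so nothing is yet known about how changes to the amide aryl group move the read-out.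

Compound 3 `CCN1CCN(c2cc(C)c3cc(NC(=O)c4ccco4)ccc3n2)CC1` is the unmeasured variant of compound 1. The change is furan-2-yl in place of 3,5-dichlorophenyl on a carbonyl carbon. The two compounds share everything else, and the amide-type nitrogen that carries the carbonyl is untouched.

For the measured compounds named here, with no measured step to lean on, the direction is a guess. The expectation is that the step of a 1.6-fold higher number from compound 1 to compound 3 (0.22 log units; within the scatter) is a modest move toward a higher number, though a result within the scatter of compound 1 would not be surprising. Compound 3 is estimated at 10000 nM, with a range from 3000 nM to 40000 nM.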

Compound 3, half-maximal inhibitory concentration: 41200 nM
The estimate for compound 3 lay 4.1-fold (0.61 log units) below the measured number; the whole stated range lies below it.
By their numbers in this assay, from the lowest: compound 2; then compound 1; then compound 3.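

In this assay, the exchange at the amide aryl group gives the series its first single-change step, a 6.8-fold higher number from compound 1 to compound 3 (0.83 log units; beyond the scatter) with the rest of the structure held constant, so the group on this carbonyl carbon clearly affects the read-out and furan-2-yl is a poorer choice here than 3,5-dichlorophenyl. The step changes several things at once: both chlorine atoms leave, the six-membered carbon ring gives way to a five-membered ring, and a ring oxygen enters, so this one pair cannot assign the loss to any of these alone. No measured property of these compounds bears on the size of this step.

Still open, going by these compounds, is where an unsubstituted phenyl or a thiophen-2-yl on the same carbonyl carbon would fall relative to compound 1 and compound 3, a comparison that could separate the loss of chlorine from the change of ring. Among the compounds shown here, also open is whether furan-2-yl has a similar effect alongside the side chain of compound 2, which differs from compound 1 in more than one place and so offers no step.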